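A few compounds are considered here, and "the series" means these few. Any claim that something is new, unique, unknown or untested is made for them only; others in the source may bear on it.

In an assay on L1.2 cells for binding affinity to C-C chemokine receptor type 8 (Homo sapiens) (a higher number here means a weaker inhibitor, a lower number a stronger inhibitor), compound 3 `Cc1ccccc1C(=O)Nc1ccc(S(=O)(=O)NC2CCN(C(N)=O)CC2)c2ccccc12` gives 243 nM, the highest number among the three measured compounds. Compound 1 `Cc1ccccc1C(=O)Nc1ccc(S(=O)(=O)NC2CCN(C(=O)CO)CC2)c2ccccc12` gives 5.4 nM and compound 2 `Cc1ccccc1C(=O)Nc1ccc(S(=O)(=O)NC2CCN(C(=O)CCCN)CC2)c2ccccc12` gives 1.6 nM; the steps of a 45-fold higher number from compound 1 to compound 3 (1.65 log units; beyond the scatter) and a 150-fold higher number from compound 2 to compound 3 (2.18 log units; beyond the scatter) show how far compound 3 falls behind both. Compound 4 `Cc1ccccc1C(=O)Nc1ccc(S(=O)(=O)NC2CCN(C(=O)N3CCC3)CC2)c2ccccc12` differs from compound 3 by azetidin-1-yl in place of amino on a carbonyl carbon. Among the measured compounds shown here, no measured step swaps amino for a ring, so the bearing is indirect: both steps into compound 3 put amino on the carbonyl in place of a carbon-bearing group and gave large rises, whereas a 3.4-fold lower number from compound 1 to compound 2 (0.53 log units; beyond the scatter) was modest. Compound 4, which brings carbon back onto the carbonyl, is therefore expected to show a lower number, a step of an 8.1-fold lower number from compound 3 to compound 4 (0.91 log units; beyond the scatter). Compound 4 is estimated at 30 nM, within 5 nM to 150 nM.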

Compound 4, inhibition constant: 3.5 nM
The estimate for compound 4 lay 8.6-fold (0.93 log units) above the measured number, outside the stated range (below it).
By their numbers in this assay, from the lowest: compound 2; then compounds 4 and 1 (each within the scatter of the next); then compound 3.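

In this assay, a nitrogen on the carbonyl carbon does not by itself go with a high number, since azetidin-1-yl in place of amino gives a large drop (a 69-fold lower number from compound 3 to compound 4 (1.84 log units; beyond the scatter)). Against hydroxymethyl, the ring shows no real difference (a 1.5-fold lower number from compound 1 to compound 4 (0.19 log units; within the scatter)), while against 3-aminopropyl it gives up a modest amount (a 2.2-fold higher number from compound 2 to compound 4 (0.34 log units; beyond the scatter)). Nothing shown here explains why amino stands apart. As far as these compounds go, whether a methylamino or dimethylamino group would follow amino or azetidin-1-yl remains open. So does whether a larger ring, such as pyrrolidin-1-yl, would keep the low number.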